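A few compounds are considered here, and "the series" means these few. Any claim that something is new, unique, unknown or untested is made for them only; others in the source may bear on it.

Measured so far:
compound 1, `CCCCCCCCCCc1cc2cn(COCCO)c(O)nc-2n1`: 80000 nM
compound 2, `CCCCCCCCCc1cc2cn(COCCO)c(=O)nc2o1`: >= 16000 nM
compound 3, `C#Cc1cn(COCCO)c(=O)[nH]c1=O`: > 400000 nM

Going by the values given here, in a functional assay on HEL cells (Homo sapiens), read by microscopy (on this read-out lower numbers stand for higher toxicity in this test and higher numbers for lower toxicity in this test), compound 1 gives 80000 nM, the only plain number in the set. For compound 2 the value >= 16000 nM is a limit of the assay and not a number. For compound 3 the value > 400000 nM is likewise a limit. Compound 4, `CCCCCc1cc2cn(COCCO)c(O)nc-2n1`, has not been measured; it differs from compound 1 by hydrogen in place of pentyl on a saturated chain carbon, five bonds along the chain from an aromatic carbon. Among the compounds with values here, no step between measured compounds is available, so the size of this change cannot be read from the data. The shorter chain is expected to push the read-out upward, beyond the scatter, toward lower toxicity. Compound 4 is therefore estimated at 200000 nM, within 60000 nM to 800000 nM, the expected step being a 2.5-fold higher number from compound 1 to compound 4 (0.40 log units; beyond the scatter).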

Compound 4, minimum cytotoxic concentration: > 400000 nM
Compound 4 ended at the assay's limit; the forecaster's own chance of this, stated with the estimate: 40%; middle value at least 2.0-fold (0.30 log units) away from the limit.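

In this assay, going by these compounds alone, hydrogen in place of pentyl on a saturated chain carbon, five bonds along the chain from an aromatic carbon, gives an at least 5.0-fold higher number from compound 1 to compound 4 (0.69 log units; beyond the scatter), the first readable step and the first sign that the outer part of this chain matters in this test. For compound 4, > 400000 nM is a limit of the assay and not a number. The full size of the step therefore stays unread: the limit of > 400000 nM in this assay, at which 2 of the 4 values shown sit.

Still open, as far as these compounds go, is where a heptyl chain on the shared core would fall relative to compound 1 and compound 4. Also open, from the compounds shown here alone, is how an amine or a carboxylic acid on the chain would read.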